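This account rests on a few compounds, and the source may have more. Where it says the series, first, only, none or still open, it means among the compounds named here.

Measured so far in a functional assay on the whole organism with Rattus norvegicus as the target; on this read-out lower numbers stand for an effect already at smaller amounts and higher numbers for an effect only at larger amounts of compound:
- compound 1 `CCOC(=O)C(=O)Nc1nc(-c2cc(OC)ccc2OC)cs1`: > 10 mg/kg, a limit
- compound 2 `CCOC(=O)C(=O)Nc1nc(-c2ccc(OC)cc2O)cs1`: about 1 mg/kg
- compound 3 `CCOC(=O)C(=O)Nc1nc(-c2ccc(-c3ccccc3)cc2O)cs1`: > 10 mg/kg, a limit

Compound 3 stands at > 10 mg/kg, which is a limit and not a number. Compound 1 shares this position: the limit of > 10 mg/kg in this assay, at which 2 of the 3 values shown sit.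

Compound 4 `O=C(O)C(=O)Nc1nc(-c2ccc(-c3ccccc3)cc2O)cs1` has hydrogen in place of ethyl on an oxygen next to a carbonyl group. Within the data shown here, the only measured step, an at least 10-fold higher number from compound 2 to compound 3 (1.00 log units; beyond the scatter), is phenyl in place of methoxy on an aromatic carbon. Among the measured compounds shown here, it lies at another place, so no measured step gives a size for this change. No clear shift in this assay is therefore expected, and the expected change is a number no higher from compound 3 to compound 4 (the limit leaves the size open). Compound 4 is estimated at 10 mg/kg, with an expected range of 2 mg/kg to 40 mg/kg.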

Compound 4, dose for half-maximal effect: > 30 mg/kg
Compound 4: no number, only a limit; the forecaster's own chance of this, stated with the estimate: 50%; at least 3.0-fold (0.47 log units) between middle value and limit.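

Compound 3 and compound 4 both carry only limits, and no step can be read between them. The compounds shown leave open whether going from ethoxycarbonyl to carboxy shifts the read-out at all, and in which direction.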